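Moving the bromine on the benzyl group of compound 3

The source may report more compounds than this note shows. Statements on the series, on what has been measured and on what is new or still open speak of the compounds shown alone.

Measured compounds:
compound 1, `Cc1cccc(Cn2cc(COc3ccc4c(=O)ccoc4c3)nn2)c1`: 22400 nM
compound 2, `O=c1ccoc2cc(OCc3cn(Cc4cccc(F)c4)nn3)ccc12`: > 100000 nM
compound 3, `O=c1ccoc2cc(OCc3cn(Cc4ccccc4Br)nn3)ccc12`: > 100000 nM

In a functional assay on QGY7701 cells (Homo sapiens) for cytotoxicity, read by MTT assay, with a stated time of 48 h (on this read-out higher numbers stand for weaker inhibition and lower numbers for stronger inhibition), compound 1 gives 22400 nM. For compound 2 the reading is a limit of the assay, > 100000 nM. For compound 3 the reading is likewise a limit of the assay, > 100000 nM, so compound 3 stands at the weak end of what has been measured (the limit of > 100000 nM in this assay, at which 2 of the 3 values shown sit). Compound 4, `O=c1ccoc2cc(OCc3cn(Cc4cccc(Br)c4)nn3)ccc12`, differs from compound 3 by 3-bromophenyl in place of 2-bromophenyl on a saturated chain carbon bound to an aromatic nitrogen. The steps that touch compound 3 are an at least 4.4-fold higher number from compound 1 to compound 3 (0.64 log units; beyond the scatter) and a step that the two limits leave unreadable from compound 2 to compound 3, the second left unreadable by its two limits. Compound 4 is therefore expected to remain near the limit, with a step of an at least 1.2-fold lower number from compound 3 to compound 4 (0.09 log units; that floor lies within the scatter) that cannot be resolved. The estimate for compound 4 is 80000 nM, between 20000 nM and 300000 nM.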

Compound 4, half-maximal inhibitory concentration: 17600 nM
The estimate for compound 4 lay 4.5-fold (0.66 log units) above the measured number; measured number below the stated range.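

In this assay, 3-bromophenyl in place of 2-bromophenyl on a saturated chain carbon bound to an aromatic nitrogen gives an at least 5.6-fold lower number from compound 3 to compound 4 (0.75 log units; beyond the scatter), so these two groups with the same atoms are not interchangeable here. Bromo in place of fluoro on an aromatic carbon gives an at least 5.6-fold lower number from compound 2 to compound 4 (0.75 log units; beyond the scatter), while bromo in place of methyl gives a 1.3-fold lower number from compound 1 to compound 4 (0.10 log units; within the scatter), so the 3-bromophenyl and 3-methylphenyl groups read alike. Compound 2 and compound 3 remain at a limit of the assay: the limit of > 100000 nM in this assay, at which 2 of the 4 values shown sit.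

Going by these compounds, whether an amine or a carboxylic acid in place of the bromo on the 3-bromophenyl group would keep this reading stays open.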